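This account rests on a few compounds, and the source may have more. Where it says the series, first, only, none or still open, it means among the compounds named here.

Within the data shown here, in a functional assay on MDA-MB-231 cells (Homo sapiens) for cytotoxicity, read by MTT assay, with a stated time of 72 h (on this read-out lower numbers stand for stronger inhibition and higher numbers for weaker inhibition), compound 1 `CCN(CC)Cc1ccc2nc(NC(=O)N/N=C/c3cn(Cc4ccc(Cl)cc4Cl)c4ccccc34)sc2c1` gives 3280 nM and compound 2 `CCN(CC)Cc1ccc2nc(NC(=O)N/N=C/c3cn(Cc4cccc(Cl)c4)c4ccccc34)sc2c1` gives 2050 nM, so compound 2 stands within the scatter of the only other measured number. Compound 3 `CCN(CC)Cc1ccc2nc(NC(=O)N/N=C/c3cn(Cc4ccc(C)cc4)c4ccccc34)sc2c1` has not yet been measured. The change is 4-methylphenyl in place of 3-chlorophenyl on a saturated chain carbon bound to an aromatic nitrogen, with 4-methylphenyl in place of 3-chlorophenyl on a saturated chain carbon bound to an aromatic nitrogen. Among the measured compounds shown here, the one measured step at this place is a 1.6-fold lower number from compound 1 to compound 2 (0.20 log units; within the scatter). For the measured compounds named here, with only that step as a guide, no change beyond the scatter is expected in this assay. The expected step is a 1.2-fold higher number from compound 2 to compound 3 (0.07 log units; within the scatter). The estimate for compound 3 is 2400 nM, with an expected range of 1000 nM to 6000 nM.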

Compound 3, half-maximal inhibitory concentration: 2010 nM
Compound 3: middle estimate off by 1.2-fold (0.08 log units), on the high side, and the stated range covers the measured number.
By their numbers in this assay, from the lowest: compounds 3, 2 and 1 (each within the scatter of the next).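

In this assay, 4-methylphenyl in place of 3-chlorophenyl on a saturated chain carbon bound to an aromatic nitrogen gives a 1.0-fold lower number from compound 2 to compound 3 (0.01 log units; within the scatter), and 4-methylphenyl in place of 2,4-dichlorophenyl gives a 1.6-fold lower number from compound 1 to compound 3 (0.21 log units; within the scatter). The earlier pair held only chlorinated phenyl groups, whereas these steps show that a methyl-bearing phenyl group without chlorine also stays within the scatter of both. All substituents shown at this position are chlorine or methyl on a phenyl ring, so the outcome with an amine, a carboxylic acid or a longer chain remains open. No available evidence bears on this result.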